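A few compounds are considered here, and "the series" means these few. Any claim that something is new, unique, unknown or untested is made for them only; others in the source may bear on it.

In a functional assay on MCF7 cells (Homo sapiens) for inhibition, read by MTT assay, with a stated time of 24 h (on this read-out lower numbers stand for stronger inhibition of growth and higher numbers for weaker inhibition of growth), the measured compounds read as follows. Compound 1 `COc1ccc2c(c1)c(-c1nc3ccccc3n1C(=O)c1ccccc1)cn2C` gives 38400 nM. Compound 2 `COc1ccc2c(c1)c(-c1nc3ccccc3n1C(=O)c1ccccc1OC)cn2C` gives 23900 nM. Compound 3 `COc1ccc2c(c1)c(-c1nc3ccccc3n1C(=O)c1ccc(OC)c(OC)c1)cn2C` gives 6300 nM.

Compound 2 differs from compound 1 by methoxy in place of hydrogen on an aromatic carbon, a step of a 1.6-fold lower number from compound 1 to compound 2 (0.21 log units; within the scatter). Compound 3 differs from compound 1 by 3,4-dimethoxyphenyl in place of phenyl on a carbonyl carbon, a step of a 6.1-fold lower number from compound 1 to compound 3 (0.78 log units; beyond the scatter). Compound 4 `COc1ccc2c(c1)c(-c1nc3ccccc3n1C(=O)c1cc(OC)c(OC)c(OC)c1)cn2C` has not yet been measured; it differs from compound 3 by methoxy in place of hydrogen on an aromatic carbon. This is the same kind of change as from compound 1 to compound 2, though the surroundings differ: there the new group sat ortho to a large group, here it sits ortho to a methoxy group, meta to a large group and meta to a methoxy group. Resting on the earlier step of a 1.6-fold lower number from compound 1 to compound 2 (0.21 log units; within the scatter), compound 4 is expected to show a 1.4-fold lower number from compound 3 to compound 4 (0.15 log units; within the scatter). Compound 4 is estimated at 4500 nM, likely between 1500 nM and 13000 nM.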

Compound 4, concentration for 50% growth inhibition: 5100 nM
Compound 4: the middle estimate sits 1.1-fold (0.05 log units) below what was measured; low and high end bracket the measured number.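

In this assay, methoxy in place of hydrogen gives a 1.2-fold lower number from compound 3 to compound 4 (0.09 log units; within the scatter), and this small step agrees with the one seen on the other core: the same change on two cores in this assay, a 1.6-fold lower number (0.21 log units; within the scatter) from compound 1 to compound 2 and a 1.2-fold lower number (0.09 log units; within the scatter) from compound 3 to compound 4, 1.3-fold (0.11 log units) apart, within the scatter of two such steps

Across these two pairs, then, the change carries over as a step too small to separate from the scatter of repeated measurements. Two pairs cannot show whether the change has a small real effect or none, nor how it would read on a different core or at another place on the ring.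

The groups added to the phenyl on the carbonyl carbon are all methoxy. As far as these compounds go, how an amine, a carboxylic acid or a longer chain such as butoxy would read there remains open.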